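Swapping Methoxy for Fluoro on a Weak Growth Inhibitor

The source may hold more compounds than are shown below. What is called first, only, known or untested is meant among the compounds shown, and "the series" means these compounds.

Of the compounds shown here, three built on one shared core have been tested in a functional assay on OVCAR-8 cells (Homo sapiens) for inhibition, read by sulforhodamine B assay, with a stated time of 48 h; on this read-out lower numbers stand for stronger inhibition of growth and higher numbers for weaker inhibition of growth. Compound 1 `CCOC(=O)[C@H](CCC(=O)O)NC(=O)c1ccc(CNc2nc3cc(N)cc(N)c3nc2-c2ccccc2)cc1` reaches only the assay limit of < 100000 nM in this assay, which is a boundary of the measurement and not a number. Compound 2 `CCOC(=O)[C@H](CCC(=O)O)NC(=O)c1ccc(Oc2nc3cc(N)cc(N)c3nc2-c2ccccc2)cc1` gives 38000 nM in this assay. Compound 3 `COc1ccc(Sc2nc3cc(N)cc(N)c3nc2-c2ccccc2)cc1` also stops at a limit, < 100000 nM in this assay, so no true number for it exists. Where compound 3 stands is therefore told only by the limit of < 100000 nM in this assay, at which 2 of the 3 values shown sit; it is simply among the weaker growth inhibitors of this small set, and the methoxy group it carries on its phenyl ring gives no numbered anchor.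

Compound 4 `Nc1cc(N)c2nc(-c3ccccc3)c(Sc3ccc(F)cc3)nc2c1` is the next step. It differs from compound 3 by fluoro in place of methoxy on an aromatic carbon, a small swap on the phenylsulfanyl arm. Going by the values given here, no pair of measured compounds shows what this exchange does in this assay, so the expectation rests on the limit alone. A change no larger than the usual scatter is expected, with compound 4 estimated at 70000 nM in this assay, within a range from 20000 nM to 200000 nM. The step this estimate means, a step that the limit leaves unreadable from compound 3 to compound 4, is expected to leave compound 4 close to the limit, quite possibly again reported only as a limit.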

Compound 4, concentration for 50% growth inhibition: 16600 nM
Compound 4: the middle estimate sits 4.2-fold (0.62 log units) above what was measured; the measured number lies below the stated range.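

Compound 3 has only an assay limit and no true number, so the change from compound 3 to compound 4 has no readable size. What fluoro in place of methoxy does in this assay stays open, as the compounds shown include no pair differing in that one place with numbers on both sides.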